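Trichloroethyl Ester in Place of Isobutyl Ester

The compounds below may be only part of what the source reports. "The series", "measured", "known", "first", "only" and "open" are said of these compounds alone.

Compound 1 `CCOc1cc(NC(=O)C2(NC(=O)c3ccc4c(C5CCCC5)c(-c5ncc(Cl)cn5)n(C)c4c3)CCC2)ccc1/C=C/C(=O)N[C@@H](CC(=O)O)C(N)=O`: 0.0667 h
Compound 2 `CCOc1cc(NC(=O)C2(NC(=O)c3ccc4c(C5CCCC5)c(-c5ncc(Cl)cn5)n(C)c4c3)CCC2)ccc1/C=C/C(=O)N[C@@H](CCC(=O)O)C(N)=O`: 4.23 h
Compound 3 `CCOc1cc(NC(=O)C2(NC(=O)c3ccc4c(C5CCCC5)c(-c5ncc(Cl)cn5)n(C)c4c3)CCC2)ccc1/C=C/C(=O)OCC(C)C`: > 5 h

In an ADME assay for pharmacokinetics, in simulated intestinal fluid (on this read-out lower numbers stand for a shorter-lived compound and higher numbers for a longer-lived compound), compound 3 reaches the upper limit of the assay, > 5 h, so only a floor is known (the limit of > 5 h in this assay, at which 1 of the 3 values shown sits). The step from the carboxy acid gave an at least 74-fold higher number from compound 1 to compound 3 (1.87 log units; beyond the scatter), while an at least 1.1-fold higher number from compound 2 to compound 3 (0.07 log units; that floor lies within the scatter). Compound 4 `CCOc1cc(NC(=O)C2(NC(=O)c3ccc4c(C5CCCC5)c(-c5ncc(Cl)cn5)n(C)c4c3)CCC2)ccc1/C=C/C(=O)OCC(Cl)(Cl)Cl` is the ester with trichloromethyl in place of isopropyl on a saturated chain carbon bound to an oxygen next to a carbonyl group. Among the measured compounds shown here, none of the measured steps alters the alkyl part of the ester; both steps into compound 3 replace the entire amino portion. The change is therefore expected to give an at least 1.2-fold lower number from compound 3 to compound 4 (0.09 log units; that floor lies within the scatter), not beyond the scatter. Compound 4 is estimated at 4 h, within 1.2 h to 5 h.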

Compound 4, half-life: > 5 h
Compound 4: only a limit was reported (the forecaster's own chance of this, stated with the estimate: 45%); middle value at least 1.2-fold (0.09 log units) away from the limit.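

In this assay compound 4 gives > 5 h, which is a limit of the assay. The step between the two esters cannot be read, but the 2,2,2-trichloroethyl ester keeps an at least 74-fold higher number from compound 1 to compound 4 (1.87 log units; beyond the scatter), while the comparison with the glutamine-type amide gives only an at least 1.1-fold higher number from compound 2 to compound 4 (0.07 log units; that floor lies within the scatter). Trichloromethyl in place of isopropyl therefore leaves this ester at the same ceiling, so a second alkyl ester now sits there: the limit of > 5 h in this assay, at which 2 of the 4 values shown sit.

Going by these compounds, how far compound 3 and compound 4 lie apart remains open. So does the behaviour of a methyl ester or a tert-butyl ester at this carbonyl carbon.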